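A few compounds are considered here, and "the series" means these few. Any claim that something is new, unique, unknown or untested is made for them only; others in the source may bear on it.

Of the compounds shown here, two have so far been measured in a functional assay on HCT-116 cells (Homo sapiens) for antiproliferative activity, read by WST assay, with a stated time of 72 h; a higher number here means that more compound is needed for the effect, a lower number that less compound is needed. Compound 1 (`CCCCNCCCCC(=O)Nc1ccc(/C(N)=N/O)cc1`) gives 516000 nM, the higher of the two numbers. Compound 2 (`CCCCCCNCC(=O)Nc1ccc(/C(N)=N/O)cc1`) gives 124000 nM, a lower number by a margin beyond the usual scatter, so less of compound 2 is needed for the effect. The next compound to be tested is compound 3 (`CCCCCCNCCCC(=O)Nc1ccc(/C(N)=N/O)cc1`). Relative to compound 1, it has hexylamino in place of (butylamino)methyl on a saturated chain carbon, three bonds along the chain from a carbonyl carbon. Among the measured compounds shown here, no two measured compounds differ in one place only, so the size of this change has not been observed directly. The expectation rests on compound 2, which also carries hexylamino and gives 124000 nM. A moderate step towards a lower number is therefore expected in this assay, although one within the scatter cannot be ruled out. That expected change is estimated as a 3.0-fold lower number from compound 1 to compound 3 (0.48 log units; beyond the scatter). For compound 3 the estimated value is 170000 nM, with an expected range from 60000 nM to 450000 nM.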

Compound 3, half-maximal effective concentration: 312000 nM
Compound 3: the middle estimate sits 1.8-fold (0.26 log units) below what was measured; low and high end bracket the measured number.
By their numbers in this assay, from the lowest: compound 2; then compounds 3 and 1 (each within the scatter of the next).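

Among the compounds shown here, the step of a 1.7-fold lower number from compound 1 to compound 3 (0.22 log units; within the scatter) is the first change that can be read directly, and in this assay it lies within the scatter. At this place, on a saturated chain carbon, three bonds along the chain from a carbonyl carbon, (butylamino)methyl with 6 heavy atoms can therefore give way to hexylamino with 7 heavy atoms without a change that this assay can distinguish; both groups have no ring, 1 hydrogen-bond donor, 1 hydrogen-bond acceptor and no net charge. No measurement is available that would explain this result or link it to any property of either group.

Going by these compounds, it remains open whether octylamino, a longer chain than hexylamino, or a piperidine ring at this same place would give a step beyond the scatter in this assay. On these data alone, it is also open whether a carboxylic acid at this place, with no amine in the chain, would give a number that stands apart from those of compound 1 and compound 3.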